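Nitro in Place of Chloro: Compound 3 to Compound 4

This account rests on a few compounds, and the source may have more. Where it says the series, first, only, none or still open, it means among the compounds named here.

The series shares one core carrying different aryl groups on an amide-type nitrogen. In a functional assay on HEK293 cells for agonist activity at D(4) dopamine receptor (Homo sapiens), read by FLIPR (a lower number here means that less compound is needed, a higher number that more compound is needed for the effect), compound 1 `Cc1cc(NC(=O)CN2CCC(c3cccc[n+]3[O-])CC2)ccc1F` gives 18 nM. Compound 2 `O=C(CN1CCC(c2cccc[n+]2[O-])CC1)Nc1ccc(F)cc1F` gives 103 nM in this assay, a change of a 5.7-fold higher number from compound 1 to compound 2 (0.76 log units; beyond the scatter). Compound 3 `Cc1ccc(Cl)cc1NC(=O)CN1CCC(c2cccc[n+]2[O-])CC1` gives 126 nM in this assay, the highest of the three numbers; the step of a 7.0-fold higher number from compound 1 to compound 3 (0.85 log units; beyond the scatter) lies beyond the scatter, while a 1.2-fold higher number from compound 2 to compound 3 (0.09 log units; within the scatter) does not, so compounds 2 and 3 cannot be set apart. Compound 4 `Cc1ccc([N+](=O)[O-])cc1NC(=O)CN1CCC(c2cccc[n+]2[O-])CC1` differs from compound 3 by nitro in place of chloro on an aromatic carbon. For the measured compounds named here, no measured step exchanges chloro for nitro, and the three measured steps concern other exchanges on the same nitrogen, so none bears directly on this change; they show only that the series spans a modest range in this assay. A step of the size seen among the measured compounds, in either direction, is therefore plausible, and the estimate for compound 4 is 150 nM, with a range from 45 nM to 500 nM. This expectation corresponds to a 1.2-fold higher number from compound 3 to compound 4 (0.08 log units; within the scatter).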

Compound 4, half-maximal effective concentration: 134 nM
For compound 4 the middle estimate is 1.1-fold (0.05 log units) above the measured one; measured number inside the range.
By their numbers in this assay, from the lowest: compound 1; then compounds 2, 3 and 4 (each within the scatter of the next).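

In this assay nitro in place of chloro on this aromatic carbon, meta to a large group and para to a methyl group, gives a 1.1-fold higher number from compound 3 to compound 4 (0.03 log units; within the scatter) and so leaves the two compounds unseparated. The earlier steps shown here each exchanged the whole aryl pattern, whereas this one changes a single group and shows that nitro, with more heavy atoms and hydrogen-bond acceptors than chloro, gives a number that cannot be told apart from that of chloro here. No measurement at hand offers an explanation for this result.

As far as these compounds go, whether the same would hold for other groups at this position, such as an amine, a carboxylic acid or a nitrile, remains open. So does whether it would hold with an ethyl group in place of the methyl group.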